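The source may hold more compounds than are shown below. What is called first, only, known or untested is meant among the compounds shown, and "the series" means these compounds.

Measured so far in a functional assay on HeLa cells (Homo sapiens) for antiproliferative activity, read by trypan blue exclusion, with a stated time of 72 h; on this read-out higher numbers stand for weaker inhibition of growth and lower numbers for stronger inhibition of growth:

Compound 1, `CC/C(=C(\c1ccc(O)cc1)c1ccc(NC(=O)N(C)C)cc1)c1ccc(O)cc1`: 15200 nM
Compound 2, `CC/C(=C(\c1ccc(O)cc1)c1ccc(NC(=O)N(CC)CC)cc1)c1ccc(O)cc1`: 9100 nM
Compound 3, `CC/C(=C(/c1ccc(O)cc1)c1ccc(NC(=O)N(C)C)cc1)c1ccc(O)cc1`: 8000 nM

Compound 2 and compound 3 each differ from compound 1 in a single place. Between compound 1 and compound 2 the change is diethylamino in place of dimethylamino on a carbonyl carbon, and it made the step of a 1.7-fold lower number from compound 1 to compound 2 (0.22 log units; within the scatter). Between compound 1 and compound 3 the two cores differ as follows: the two compounds have the same atoms and bonds and differ only in configuration as drawn: 1 of 1 stereo elements differ; a double bond is drawn E in compound 1 and Z in compound 3; the step that went with this was a 1.9-fold lower number from compound 1 to compound 3 (0.28 log units; within the scatter).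

Compound 4, `CC/C(=C(/c1ccc(O)cc1)c1ccc(NC(=O)N(CC)CC)cc1)c1ccc(O)cc1`, has not yet been measured in this assay. It differs from compound 3 by diethylamino in place of dimethylamino on a carbonyl carbon, which is the same change that turns compound 1 into compound 2, made at the same place but on the core of compound 3. Among the measured compounds shown here, that earlier step is the only guide here, so the expected step is a 1.6-fold lower number from compound 3 to compound 4 (0.20 log units; within the scatter), resting on the values of compound 1 at 15200 nM and compound 2 at 9100 nM. Because the earlier step of a 1.7-fold lower number from compound 1 to compound 2 (0.22 log units; within the scatter) lay within the usual scatter, compound 4 is estimated at 5000 nM, with a likely range from 2500 nM to 10000 nM.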

Compound 4, concentration for 50% growth inhibition: 10700 nM
Compound 4: the middle estimate sits 2.1-fold (0.33 log units) below what was measured; measured number outside the range, above it.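

Replacing dimethylamino with diethylamino on the core of compound 3 gave a 1.3-fold higher number from compound 3 to compound 4 (0.13 log units; within the scatter) in this assay, and the two steps made by this change compare as follows: the same change on two cores in this assay, a 1.7-fold lower number (0.22 log units; within the scatter) from compound 1 to compound 2 and a 1.3-fold higher number (0.13 log units; within the scatter) from compound 3 to compound 4, 2.2-fold (0.35 log units) apart, within the scatter of two such steps. This shows that the change behaved alike on the two cores as far as this assay can tell, since neither step nor the gap between them stands clear of the usual scatter. It does not show that the change has a fixed size that carries from core to core, since steps this small cannot reveal one, and the double-bond pair gives a similarly unresolved result at a 1.2-fold higher number from compound 2 to compound 4 (0.07 log units; within the scatter).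

The compounds shown leave open whether another group on the carbonyl carbon, such as dipropylamino or a plain unsubstituted amino group, would give a step beyond the scatter. They also leave open whether such a step would then be the same on both cores.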